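Swapping the Aryl Ring of a Hydrazone Inhibitor

The source may hold more compounds than are shown below. What is called first, only, known or untested is meant among the compounds shown, and "the series" means these compounds.

Compound 1 `COc1ccc(/C=N/N(Cc2ccccc2)Cc2ccccc2)cc1` carries a 4-methoxyphenyl on the carbon that is double-bonded to nitrogen. Among the measured compounds shown here, in an assay on liver (Sus scrofa) for inhibition of glucose-6-phosphatase catalytic subunit 1 (Homo sapiens), using microsomes (a lower number here means a stronger inhibitor, a higher number a weaker inhibitor), compound 1 gives 220 nM, the lower of the two numbers measured so far. Compound 2 `CN(C)c1ccc(/C=N/N(Cc2ccccc2)Cc2ccccc2)cc1` differs by a dimethylamino in place of methoxy on an aromatic carbon; in this assay compound 2 gives 100000 nM, and the step is a 450-fold higher number from compound 1 to compound 2 (2.66 log units; beyond the scatter). Compound 3 `Clc1cc(Cl)cc(/C=N/N(Cc2ccccc2)Cc2ccccc2)c1` has not been measured; its change from compound 1 is 3,5-dichlorophenyl in place of 4-methoxyphenyl on a carbon with a double bond to nitrogen. For the measured compounds named here, the single measured step altered the same ring in a different way, so it bears on this change only loosely, but it does show that altering that ring can move the number a great deal. Going by the values given here, with no measured step showing this particular exchange, a weaker result is expected only tentatively. Compound 3 is expected to give about 2000 nM, within 200 nM to 30000 nM, which is estimated to mean a 9.1-fold higher number from compound 1 to compound 3 (0.96 log units; beyond the scatter).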

Compound 3, half-maximal inhibitory concentration: > 100000 nM
Compound 3: no number, only a limit; the forecaster's own chance of this, stated with the estimate: 15%; middle value at least 50-fold (1.69 log units) from the limit.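

The reading for compound 3 is a limit and not a number: the limit of > 100000 nM in this assay, at which 1 of the 3 values shown sits.

Exchanging 4-methoxyphenyl for 3,5-dichlorophenyl on this carbon gives an at least 450-fold higher number from compound 1 to compound 3 (2.65 log units; beyond the scatter). Compound 2 had shown one replacement at this ring raising the number; compound 3 shows that a second, quite different one, which removes the oxygen and brings in chlorine, raises it too, so among the compounds shown only compound 1 gives a low number.

As far as these compounds go, what stays open is whether losing the methoxy or gaining the two chlorines counts for more, for both happen in a single step. Also open, from the compounds shown here alone, is how this carbon would fare with a plain phenyl, or with a ring carrying a hydroxyl or an ethoxy group.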